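Formylamino for Acetoxy: From Compound 3 to Compound 4

The source may report more compounds than this note shows. Statements on the series, on what has been measured and on what is new or still open speak of the compounds shown alone.

In a functional assay on NCI-H460 cells (Homo sapiens) (on this read-out lower numbers stand for an effect already at smaller amounts and higher numbers for an effect only at larger amounts of compound), compound 1 (`COc1cc(C2OC(c3ccc(N(C)C)cc3)=NN2C(C)=O)cc(OC)c1OC`) gives 0.044 uM, compound 2 (`COc1cc(C2OC(c3ccc(N(C)C)cc3)=NN2C(C)=O)cc(OC)c1OC(C)=O`) gives 13 uM and compound 3 (`COc1cc(C2OC(c3ccc(N(C)C)cc3)=NN2C(=O)COC(C)=O)cc(OC)c1OC`) gives 0.072 uM. Compound 3 thus stands within the scatter of compound 1 and far under compound 2. Compound 4 (`COc1cc(C2OC(c3ccc(N(C)C)cc3)=NN2C(=O)CNC=O)cc(OC)c1OC`) carries formylamino in place of acetoxy on a saturated chain carbon bound to a carbonyl carbon. The measured step closest to this change is a 1.6-fold higher number from compound 1 to compound 3 (0.21 log units; within the scatter), which introduced acetoxy at this same place and stayed within the scatter. The other step, a 300-fold higher number from compound 1 to compound 2 (2.47 log units; beyond the scatter), is large, but it lies elsewhere on the molecule and says little about this side chain. For the measured compounds named here, no measured compound carries formylamino, so the expectation remains uncertain. A small change is expected, namely a 1.1-fold higher number from compound 3 to compound 4 (0.05 log units; within the scatter), with nothing beyond the scatter in this assay. The estimated value for compound 4 is 0.08 uM, with an expected range from 0.025 uM to 0.3 uM.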

Compound 4, concentration for half-maximal effect: 0.04 uM
Compound 4: middle estimate off by 2.0-fold (0.30 log units), on the high side; the range from low to high includes it.
By their numbers in this assay, from the lowest: compounds 4, 1 and 3 (each within the scatter of the next); then compound 2.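

For the compounds shown here, until now, acetoxy was the only group measured on this saturated chain carbon bound to a carbonyl carbon, so it was unclear whether the near-silent step from hydrogen depended on that particular group. Formylamino, which puts a nitrogen rather than an oxygen on the chain carbon and brings a hydrogen-bond donor, gives a 1.8-fold lower number from compound 3 to compound 4 (0.26 log units; within the scatter) in this assay and a 1.1-fold lower number from compound 1 to compound 4 (0.04 log units; within the scatter), so two different groups at this place now read like the hydrogen of compound 1. Nothing available explains why these groups read alike.

Going by these compounds, whether an amine, a carboxylic acid or a longer chain at this place would stay within the scatter remains open. Also open, on these data alone, is how formylamino would read alongside the acetyl on the aromatic oxygen, the change that gave a 300-fold higher number from compound 1 to compound 2 (2.47 log units; beyond the scatter).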